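Swapping Methoxy for Chloro on the Aromatic Ring

The source may hold more compounds than are shown below. What is called first, only, known or untested is meant among the compounds shown, and "the series" means these compounds.

Among the measured compounds shown here, in a functional assay on HCT-116 cells (Homo sapiens) for antiproliferative activity, read by MTT assay, with a stated time of 72 h (on this read-out lower numbers stand for stronger inhibition and higher numbers for weaker inhibition), compound 1 `Nc1nc(N)c2cc(CSC(=S)N3CCN(c4ccc(O)cc4)CC3)ccc2n1` gives 5980 nM and compound 2 `COc1ccc(N2CCN(C(=S)SCc3ccc4nc(N)nc(N)c4c3)CC2)cc1` gives 2270 nM, the lower of the two numbers so far. Compound 3 `Nc1nc(N)c2cc(CSC(=S)N3CCN(c4ccc(Cl)cc4)CC3)ccc2n1` is not yet measured. It carries chloro in place of methoxy on an aromatic carbon, para to a large group (chloro in place of methoxy on an aromatic carbon). For the measured compounds named here, the one measured step that bears on this, a 2.6-fold lower number from compound 1 to compound 2 (0.42 log units; beyond the scatter), was modest and also involved the methoxy. With so little evidence, a similarly small change is expected, with no firm direction: the expected change is a 1.2-fold higher number from compound 2 to compound 3 (0.09 log units; within the scatter). For compound 3, the estimated value is 2800 nM, within an expected range of 1000 nM to 7500 nM.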

Compound 3, half-maximal inhibitory concentration: 7380 nM
Compound 3: middle estimate off by 2.6-fold (0.42 log units), on the low side; the range from low to high includes it.
By their numbers in this assay, from the lowest: compound 2; then compounds 1 and 3 (each within the scatter of the next).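

Chloro in place of methoxy at this place gives a 3.3-fold higher number from compound 2 to compound 3 (0.51 log units; beyond the scatter) in this assay and so gives up the advantage that compound 2 held over compound 1. Chloro in place of hydroxy gives a 1.2-fold higher number from compound 1 to compound 3 (0.09 log units; within the scatter) and so separates neither group from the other, which leaves methoxy as the only one of the three groups that stands apart here. Nothing shown gives a reason for this. Whether the advantage belongs to methoxy alone stays open: the compounds shown do not tell how an ethoxy group, a methyl group or an amine would fare on this aromatic carbon.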